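The compounds below may be only part of what the source reports. "The series", "measured", "known", "first", "only" and "open" are said of these compounds alone.

Measured compounds:
compound 1 `CCCc1ccc(-c2cc(=O)c3c(o2)C(CC)(CC)C(=O)C(CC)=C3O)cc1`, in a functional assay on KBVIN cells (Homo sapiens) for antiproliferative activity, read by sulforhodamine B assay, with a stated time of 3 days (on this read-out lower numbers stand for an effect already at smaller amounts and higher numbers for an effect only at larger amounts of compound), compound 1 gives 12.2 uM
compound 2 `CCC1=C(O)c2c(oc(-c3ccccc3F)cc2=O)C(CC)(CC)C1=O`, in this assay compound 2 gives 3.93 uM

Compound 2 holds the lowest of the two numbers, its nearest neighbour being compound 1, reached by a 3.1-fold lower number from compound 1 to compound 2 (0.49 log units; beyond the scatter). Compound 3 `CCC1=C(O)c2c(oc(-c3cc(C)ccc3F)cc2=O)C(CC)(CC)C1=O` differs from compound 2 by methyl in place of hydrogen on an aromatic carbon. No measured step exchanges a hydrogen for a methyl on this ring; the only step shown swaps the whole aryl group, so it gives no direct guide. With nothing pointing one way, the step in this assay is expected to stay within the scatter. Compound 3 is therefore estimated at 4 uM, between 1.5 uM and 10 uM, meaning an expected 1.0-fold higher number from compound 2 to compound 3 (0.01 log units; within the scatter).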

Compound 3, concentration for half-maximal effect: 3.24 uM
For compound 3 the middle estimate is 1.2-fold (0.09 log units) above the measured one; low and high end bracket the measured number.
By their numbers in this assay, from the lowest: compounds 3 and 2 (each within the scatter of the next); then compound 1.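

In this assay, the methyl on this aromatic carbon, para to the fluoro group and meta to the large group, gives a 1.2-fold lower number from compound 2 to compound 3 (0.08 log units; within the scatter), so this position carries a methyl with no difference beyond the scatter. With a 3.8-fold lower number from compound 1 to compound 3 (0.58 log units; beyond the scatter), the 2-fluoro-5-methylphenyl group stands clear of the 4-propylphenyl group, much as the 2-fluorophenyl group does. From the compounds shown here alone, whether an ethyl, a methoxy or an amine on this carbon would read the same remains open, as does whether the methyl would read the same without the fluoro group. No measurement at hand accounts for either step.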